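The source may report more compounds than this note shows. Statements on the series, on what has been measured and on what is new or still open speak of the compounds shown alone.

Series notes. In a functional assay for inhibition, with a stated time of 30 min, tested at 1 mM (a higher number here means more inhibition at the concentration tested (going by the name of the read-out), a lower number less inhibition), compound 1 `COc1cc(/C(Cl)=C/C=C(\C#N)C(=O)c2c[nH]c3ccccc23)cc(OC)c1OC` gives 21.1%. Compound 2 `COc1cc(/C(Cl)=C/C=C(\C#N)C(=O)c2c[nH]c3ccc(Br)cc23)cc(OC)c1OC` carries bromo in place of hydrogen on an aromatic carbon, and in this assay compound 2 gives 26.3%. Among the measured compounds shown here, the only single-change step in the measured set is a number 5.2 percentage points higher from compound 1 to compound 2 (within the scatter). Compound 3 `COc1ccc(/C(Cl)=C/C=C(\C#N)C(=O)c2c(C)[nH]c3ccccc23)cc1OC` in this assay gives 22.4%, the second highest of the three numbers; compound 1 lies nearest, lower by a margin within the scatter, and compound 2 furthest, higher by a margin also within the scatter. All three numbers thus sit together, with no separation beyond the scatter among them.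

Compound 4 `COc1cc(/C(Cl)=C/C=C(\C#N)C(=O)c2c(C)[nH]c3ccccc23)cc(OC)c1OC` is not yet measured. It differs from compound 3 by methoxy in place of hydrogen on an aromatic carbon, the entering group sitting on an aromatic carbon of a six-membered aromatic ring of carbon only, ortho to a methoxy group and meta to a methoxy group and to a large group. For the measured compounds named here, no measured step concerns this change: the one step in hand, a number 5.2 percentage points higher from compound 1 to compound 2 (within the scatter), involves bromo on another part of the core and is itself within the scatter. With nothing in the measured set pointing either way, the expected step in this assay is a number 0.4 percentage points lower from compound 3 to compound 4 (within the scatter), none beyond the scatter. The estimate for compound 4 in this assay is 22%, with a range from 12% to 32%.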

Compound 4, a percentage reported as inhibition, at one concentration (the size of the read-out at that concentration, not a potency): 14.5%
Estimate against measurement, compound 4: 7.5 percentage points above; low and high end bracket the measured number.
By their numbers in this assay, from the lowest: compounds 4, 1, 3 and 2 (each within the scatter of the next, the first and the last beyond it).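

At this position the added methoxy on the ring of carbon only, ortho to a methoxy group and meta to a methoxy group and to a large group, gives a number 7.9 percentage points lower from compound 3 to compound 4 (within the scatter) in this assay and so cannot be told apart from no change at this single concentration. Read with an added methyl group instead, the step is a number 6.6 percentage points lower from compound 1 to compound 4 (within the scatter) and also stays inside the usual spread, so neither single-site change on its own separates compound 4 from its neighbours. The first gap in the series that clears the scatter is a number 11.8 percentage points lower from compound 2 to compound 4 (beyond the scatter) and is modest, and it goes with 2-methyl-1H-indol-3-yl in place of 5-bromo-1H-indol-3-yl on a carbonyl carbon, so the bromo-bearing and methyl-bearing indolyl groups now stand apart while the ring methoxy change alone does not.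

As far as these compounds go, whether an amine or a carboxylic acid on that same aromatic carbon, or a longer chain such as ethoxy in place of the entering methoxy, would give a step beyond the scatter remains open. Nothing available explains any of these steps.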